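The compounds below may be only part of what the source reports. "The series", "measured", "known", "first", "only" and "open" are said of these compounds alone.

Measured in a functional assay on MDA-MB-231 cells (Homo sapiens) for cytotoxicity, read by MTT assay, with a stated time of 48 h; on this read-out higher numbers stand for weaker inhibition and lower numbers for stronger inhibition:

- compound 1 `CC(C)=CCC/C(C)=C/CC/C(C)=C/CSc1ccccc1C(=O)N1CCC[C@H]1C(=O)OC(C)CCOc1no[n+]([O-])c1S(=O)(=O)c1ccccc1`: 1540 nM
- compound 2 `CCC(C)Oc1no[n+]([O-])c1S(=O)(=O)c1ccccc1`: 15300 nM
- compound 3 `CC(C)=CCC/C(C)=C/CC/C(C)=C/CSc1ccccc1C(=O)N[C@@H](C)C(=O)OCCCCOc1no[n+]([O-])c1S(=O)(=O)c1ccccc1`: > 50000 nM

Compound 3 stands at the limit of > 50000 nM in this assay, at which 1 of the 3 values shown sits, so it has a limit and not a number. Compound 4 `CC(C)=CCC/C(C)=C/CC/C(C)=C/CSc1ccccc1C(=O)NCC(=O)OCCCCOc1no[n+]([O-])c1S(=O)(=O)c1ccccc1` differs from compound 3 by hydrogen in place of methyl on a saturated chain carbon bound to an amide-type nitrogen and a carbonyl carbon. Among the measured compounds shown here, no measured pair shows this change alone. The expectation therefore rests on compound 3, whose limit is > 50000 nM. In this assay, no step beyond the scatter is expected, and the assay may again report only a limit. The estimated step is an at least 1.1-fold lower number from compound 3 to compound 4 (0.04 log units; that floor lies within the scatter). For compound 4, the expected value is 45000 nM, with an estimated range of 12000 nM to 100000 nM.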

Compound 4, half-maximal inhibitory concentration: 9990 nM
The estimate for compound 4 lay 4.5-fold (0.65 log units) above the measured number; the whole stated range lies above it.
By their numbers in this assay, from the lowest: compound 1; then compounds 4 and 2 (each within the scatter of the next). At a limit, above all of these: compound 3.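

In this assay, among the compounds shown here, hydrogen in place of methyl on a saturated chain carbon bound to an amide-type nitrogen and a carbonyl carbon gives an at least 5.0-fold lower number from compound 3 to compound 4 (0.69 log units; beyond the scatter) and so shows that this one small change can move the read-out beyond the scatter, which no earlier pair could show. The step is only a floor, as compound 3 has a limit and not a number: the limit of > 50000 nM in this assay, at which 1 of the 4 values shown sits.

Only hydrogen and methyl are shown on this carbon. On these data alone, how an ethyl group, a longer chain or a hydroxymethyl group there would read remains open.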